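A few compounds are considered here, and "the series" means these few. Any claim that something is new, unique, unknown or untested is made for them only; others in the source may bear on it.

Measured in a functional assay on PC-3 cells (Homo sapiens) for cytotoxicity, read by MTT assay, with a stated time of 72 h; a lower number here means a stronger inhibitor, a higher number a weaker inhibitor:
- compound 1 `COc1cc(Nc2nc3ccccc3nc2S(=O)(=O)c2ccccc2)cc(OC)c1`: 140 nM
- compound 2 `Nc1cccc(Nc2nc3ccccc3nc2S(=O)(=O)c2ccccc2)c1`: 2150 nM

Of these two, compound 2 has the higher number, at 2150 nM, and so is the weaker inhibitor in this assay. The next analogue is compound 3 `Nc1cccc(Nc2nc3ccccc3nc2S(=O)(=O)c2ccc(Br)cc2)c1`, which has bromo in place of hydrogen on an aromatic carbon, turning the phenyl into 4-bromophenyl: bromo in place of hydrogen on an aromatic carbon. Within the data shown here, the only measured step, a 15-fold higher number from compound 1 to compound 2 (1.19 log units; beyond the scatter), is large and beyond the scatter, but it changes the group on the nitrogen and leaves the phenyl untouched. Among the measured compounds shown here, it therefore bears only indirectly, and no measured step gives the size or direction of this change. A step within the scatter is expected, with a wide margin on either side. The expected step is a 1.5-fold lower number from compound 2 to compound 3 (0.19 log units; within the scatter). The estimate for compound 3 is 1400 nM, with an expected range of 450 nM to 4000 nM.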

Compound 3, half-maximal inhibitory concentration: 9010 nM
Estimate against measurement, compound 3: 6.4-fold (0.81 log units) below; measured number outside the range, above it.
By their numbers in this assay, from the lowest: compound 1; then compound 2; then compound 3.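

In this assay the phenyl is now shown to be a site that responds to change: turning it into 4-bromophenyl, with bromo para to a large group, gives a 4.2-fold higher number from compound 2 to compound 3 (0.62 log units; beyond the scatter), a modest step beyond the scatter and towards weaker inhibition. Among these compounds, the earlier step spoke only to the group on the nitrogen, so this is the first reading at this second place, and for this one heavy atom the direction is a loss rather than a gain. Nothing at hand accounts for the step.

As far as these compounds go, whether the loss belongs to bromo alone or to any group at this carbon stays open, and fluoro, methoxy or an amine there would separate the two. Also open, from the compounds shown here alone, is whether 4-bromophenyl gives a similar step when 3,5-dimethoxyphenyl sits on the nitrogen, as in compound 1.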